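Replacing allyl with 2,2,2-trifluoroethyl on the shared core

The source may hold more compounds than are shown below. What is called first, only, known or untested is meant among the compounds shown, and "the series" means these compounds.

Compound 1 `CCOC(=O)c1ccsc1NC(=O)[C@@H]1CCCN1` and compound 2 `C=CCOC(=O)c1ccsc1NC(=O)[C@@H]1CCCN1` share one core and were both measured in a toxicity assay on HUVEC cells (Homo sapiens) for inhibition; a lower number here means a stronger inhibitor of growth, a higher number a weaker inhibitor of growth. Compound 1 gives > 250 ug/mL, which is a limit of the assay and not a number. Among the measured compounds shown here, compound 2 gives 149 ug/mL, the only true number so far. For the measured compounds named here, the single measured step is an at least 1.6-fold lower number from compound 1 to compound 2 (0.22 log units; that floor lies within the scatter), and its size is bounded only by the limit of > 250 ug/mL in this assay, at which 1 of the 2 values shown sits.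

Compound 3 `O=C(OCC(F)(F)F)c1ccsc1NC(=O)[C@@H]1CCCN1` differs from compound 2 by trifluoromethyl in place of vinyl on a saturated chain carbon bound to an oxygen next to a carbonyl group, with trifluoromethyl in place of vinyl on a saturated chain carbon bound to an oxygen next to a carbonyl group. Going by the values given here, with an at least 1.6-fold lower number from compound 1 to compound 2 (0.22 log units; that floor lies within the scatter) as the only measured change at this place, no step beyond the scatter is expected in this assay. The expected step is a 1.2-fold higher number from compound 2 to compound 3 (0.08 log units; within the scatter). For compound 3 the estimate is 180 ug/mL, with an expected range of 90 ug/mL to 300 ug/mL.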

Compound 3, concentration for 50% growth inhibition: > 250 ug/mL
Compound 3: no number, only a limit; the forecaster's own chance of this, stated with the estimate: 25%; middle value at least 1.3-fold (0.14 log units) away from the limit.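

In this assay compound 3 gives > 250 ug/mL, a limit of the assay and not a number. Among the compounds shown here, the change from allyl to 2,2,2-trifluoroethyl gives an at least 1.6-fold higher number from compound 2 to compound 3 (0.22 log units; that floor lies within the scatter), so at this position compound 2 is now the only one of the three compounds with a true number, while the ethyl of compound 1 and the 2,2,2-trifluoroethyl of compound 3 both give limits. The step between compound 1 and compound 3 cannot be read: the limit of > 250 ug/mL in this assay, at which 2 of the 3 values shown sit.

From the compounds shown here alone, how far the true values of compound 1 and compound 3 lie from that limit, and so whether the trifluoromethyl and methyl ends differ at all, stays open. Also open, going by these compounds, is whether a longer saturated chain such as butyl, or a benzyl group, at this position would give a true number as allyl does.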